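A second methyl position on the linker of compound 1

The compounds below may be only part of what the source reports. "The series", "measured", "known", "first", "only" and "open" are said of these compounds alone.

Compound 1, `Sc1nccn1CCCc1ccccc1`: 16000 nM
Compound 2, `CC(Cc1ccccc1)Cn1ccnc1S`: 29000 nM
Compound 3, `COc1ccc(CCCCn2ccnc2S)cc1`: 152000 nM

Of the compounds shown here, three sharing the same core have been tested in an assay on isolated protein for inhibition of Dopamine beta-hydroxylase (Bos taurus); on this read-out higher numbers stand for weaker inhibition and lower numbers for stronger inhibition. Compound 1 gives 16000 nM, the lowest of the three numbers. Compound 2 gives 29000 nM, which is within the scatter of compound 1, and compound 3 gives 152000 nM, which lies beyond it.

Compound 4, `CC(CCn1ccnc1S)c1ccccc1`, differs from compound 1 by methyl in place of hydrogen on a saturated chain carbon bound to an aromatic carbon and a saturated chain carbon. Within the data shown here, the one measured step that bears on this change is a 1.8-fold higher number from compound 1 to compound 2 (0.26 log units; within the scatter), where a methyl entered the same chain at a different saturated carbon and the number moved only within the scatter. Compound 3 differs from compound 1 in more than one place, so its value shows only that a longer, substituted analogue gave a higher number.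

On this basis compound 4 is expected to sit close to compound 1, with a step of a 1.3-fold higher number from compound 1 to compound 4 (0.10 log units; within the scatter) that is not expected to pass the scatter. The estimate for compound 4 is 20000 nM, in a range from 8000 nM to 50000 nM.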

Compound 4, half-maximal inhibitory concentration: 18000 nM
Estimate against measurement, compound 4: 1.1-fold (0.05 log units) above; the range from low to high includes it.
By their numbers in this assay, from the lowest: compounds 1, 4 and 2 (each within the scatter of the next); then compound 3.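

In this assay, the step at this position reads a 1.1-fold higher number from compound 1 to compound 4 (0.05 log units; within the scatter), so this saturated chain carbon bound to an aromatic carbon and a saturated chain carbon takes a methyl in place of hydrogen without the number leaving the scatter. Set beside the earlier step, a 1.8-fold higher number from compound 1 to compound 2 (0.26 log units; within the scatter), it shows the same change at two different saturated carbons of the chain of compound 1, and both steps stay within the scatter. No available evidence bears on this result.

The compounds shown leave open whether an ethyl group or an amine on this same carbon would also keep the number within the scatter of compound 1. They also leave open what two methyl groups on the one chain would do.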